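Cytotoxicity notes on a nitroimidazole series with piperidine variants

The source may report more compounds than this note shows. Statements on the series, on what has been measured and on what is new or still open speak of the compounds shown alone.

Measured compounds:
compound 1, `Cc1ncc([N+](=O)[O-])n1CC(O)CSC(=S)N1CCCCC1`: 1400000 nM
compound 2, `Cc1ncc([N+](=O)[O-])n1CC(O)CSC(=S)N1CCC(C)CC1`: 1820000 nM
compound 3, `Cc1ncc([N+](=O)[O-])n1CC(O)CN1CCCCC1`: only a limit is known

In a toxicity assay on HeLa cells (Homo sapiens) for cytotoxicity, read by MTT assay, with a stated time of 24 h (on this read-out lower numbers stand for stronger inhibition and higher numbers for weaker inhibition), compound 1 gives 1400000 nM. Compound 2 carries the change (methyl in place of hydrogen on a saturated ring carbon), and from compound 1 to compound 2 the read-out moves by a 1.3-fold higher number from compound 1 to compound 2 (0.11 log units; within the scatter). In this assay compound 3 gives only a limit of the assay, > 5000000 nM. That limit is the limit of > 5000000 nM in this assay, at which 1 of the 3 values shown sits. The difference between the core of compound 1 and the core of compound 3 is not broken down here.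

Compound 4, `Cc1ncc([N+](=O)[O-])n1CC(O)CN1CCC(C)CC1`, is not yet measured in this assay. It differs from compound 3 by methyl in place of hydrogen on a saturated ring carbon, the same change as from compound 1 to compound 2. For compound 4 the step that the limit leaves unreadable from compound 3 to compound 4 is expected to be no larger than what compound 1 to compound 2 showed, since that step was a 1.3-fold higher number from compound 1 to compound 2 (0.11 log units; within the scatter). Because compound 3 already sits at the limit > 5000000 nM, compound 4 is estimated to land near or beyond that limit, around 6000000 nM, so the measurement will most likely again return only a limit.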

Compound 4, half-maximal inhibitory concentration: > 5000000 nM
Compound 4 was reported as a limit (the forecaster's own chance of this, stated with the estimate: 80%); the middle value lies beyond the limit too.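

Among these compounds, compound 3 and compound 4 are both reported only as limits in this assay, so no step between them can be read: the limit of > 5000000 nM in this assay, at which 2 of the 4 values shown sit.

The compounds shown leave open where the true values of compound 3 and compound 4 lie, and whether methyl in place of hydrogen on a saturated ring carbon changes the read-out on the core of compound 3.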